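Removing a chloro group from compound 3

The source may report more compounds than this note shows. Statements on the series, on what has been measured and on what is new or still open speak of the compounds shown alone.

In a functional assay on Hep cells (Homo sapiens) for cytotoxicity, read by sulforhodamine B assay, with a stated time of 48 h (on this read-out lower numbers stand for stronger inhibition and higher numbers for weaker inhibition), compound 3 (`O=C(c1cccnc1)c1cc(Cl)cc(Cl)c1O`) gives 27000 nM. Compound 1 (`O=C(c1cccnc1)c1ccccc1O`) gives 31000 nM, which lies within the scatter of the value for compound 3. Compound 2 (`C=CCOc1c(Cl)cccc1C(=O)c1cccnc1`) gives 92000 nM, a higher number beyond the scatter of the value for compound 3. Compound 3 therefore sits at the low end of the series, level with compound 1.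

Compound 4 (`O=C(c1cccnc1)c1cccc(Cl)c1O`) is still unmeasured. It differs from compound 3 by hydrogen in place of chloro on an aromatic carbon, para to a hydroxy group: hydrogen in place of chloro on an aromatic carbon.

Within the data shown here, no pair of measured compounds differs in one place, so this change has no direct precedent. Compound 1, which has no chloro group, gives 31000 nM, and compound 3 gives 27000 nM. Compound 4 keeps a chloro group, so no step beyond the scatter is expected in this assay. The expected change is a 1.1-fold higher number from compound 3 to compound 4 (0.03 log units; within the scatter). For compound 4 the estimated value is 29000 nM, with an expected range from 16000 nM to 52000 nM.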

Compound 4, half-maximal inhibitory concentration: 28000 nM
Estimate against measurement, compound 4: 1.0-fold (0.02 log units) above; the measured number falls inside the stated range.
By their numbers in this assay, from the lowest: compounds 3, 4 and 1 (each within the scatter of the next); then compound 2.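

In this assay, hydrogen in place of chloro on an aromatic carbon, para to a hydroxy group, gives a 1.0-fold higher number from compound 3 to compound 4 (0.02 log units; within the scatter), so this chloro group can leave without a step beyond the scatter. Chloro in place of hydrogen on an aromatic carbon gives a 1.1-fold lower number from compound 1 to compound 4 (0.04 log units; within the scatter), so the remaining chloro group brings no such step either. Among these compounds, the only step here beyond the scatter lies at the oxygen, where hydrogen in place of allyl gives a 3.3-fold lower number from compound 2 to compound 4 (0.52 log units; beyond the scatter).

No measurement on hand explains any of these steps. Still open, as far as these compounds go, is whether an amine or a carboxylic acid para to the hydroxy group would give a step beyond the scatter, and whether methyl on the oxygen would track with allyl.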